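The source may hold more compounds than are shown below. What is called first, only, known or untested is meant among the compounds shown, and "the series" means these compounds.

Working notes on the series. In a functional assay on HL-60 cells (Homo sapiens) for cytotoxicity, read by CellTiter-Blue, with a stated time of 48 h (on this read-out higher numbers stand for weaker inhibition and lower numbers for stronger inhibition), compound 2 `CCOC(=O)CC1C(C(=O)OCC)=C(N)Oc2ccc(-c3ccc(F)cc3F)cc21` gives 76600 nM, the highest of the three numbers in hand. Compound 3 `C#CCOC(=O)CC1C(C#N)=C(N)Oc2ccc(-c3cccc(N)c3)cc21` gives 43900 nM in this assay, within the scatter of compound 2. Compound 1 `C=CCOC(=O)CC1C(C(=O)OCC=C)=C(N)Oc2ccc(-c3cc(OC)cc(OC)c3)cc21` gives 4700 nM in this assay, a lower number than compound 2, beyond the scatter. Compound 4 `CCOC(=O)CC1C(C(=O)OCC)=C(N)Oc2ccc(-c3cccc(C(N)=O)c3)cc21` is not yet measured; it differs from compound 2 in one place: 3-carbamoylphenyl in place of 2,4-difluorophenyl on an aromatic carbon. Within the data shown here, no measured pair shows a step of this kind, and the measured compounds differ in several places at once, so nothing in hand fixes its size. The expectation for compound 4 in this assay is a step of a 1.9-fold lower number from compound 2 to compound 4 (0.28 log units; within the scatter), a modest move toward a lower number, possibly none beyond the scatter. Compound 4 is estimated at 40000 nM in this assay, with a range from 10000 nM to 150000 nM.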

Compound 4, half-maximal inhibitory concentration: 5400 nM
For compound 4 the middle estimate is 7.4-fold (0.87 log units) above the measured one; measured number below the stated range.
By their numbers in this assay, from the lowest: compounds 1 and 4 (each within the scatter of the next); then compounds 3 and 2 (each within the scatter of the next).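

In this assay, among these compounds, the change of 3-carbamoylphenyl for 2,4-difluorophenyl gives a 14-fold lower number from compound 2 to compound 4 (1.15 log units; beyond the scatter) and is the first step that can be read in one place. It shows that, on the shared core of compound 2 and compound 4, the group on this aromatic carbon can by itself move the number beyond the scatter. Going by these compounds, whether the carbamoyl group, the loss of both fluorines, or both set this step stays open, as does the outcome with an unsubstituted phenyl or a carboxylic acid at that ring position. Nothing in hand accounts for the size of this step.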